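Methyl in place of hydroxy on compound 2

The source may hold more compounds than are shown below. What is called first, only, known or untested is meant among the compounds shown, and "the series" means these compounds.

In a functional assay on P388 cells (Mus musculus) for inhibition (on this read-out lower numbers stand for stronger inhibition and higher numbers for weaker inhibition), compound 1 `COc1cc2ccc(CCc3ccc4ccccc4c3)cc2cc1O` stands at 3590 nM and compound 2 `Oc1ccc(/C=C/c2ccc3ccccc3c2)cc1` stands at 4060 nM on the same read-out, so these two values lie within the scatter of each other. Going by the values given here, compound 2 therefore sits level with the only other measured compound. Compound 3 `Cc1ccc(/C=C/c2ccc3ccccc3c2)cc1` differs from compound 2 in one place. The change methyl in place of hydroxy on an aromatic carbon puts methyl in place of hydroxy on an aromatic carbon, para to a large group. Among the compounds with values here, no measured pair shows this change, and both measured compounds carry a hydroxy, so the data give no direct guide to its size. In this assay a small step toward weaker inhibition is expected, possibly not beyond the scatter. The estimate amounts to a 1.5-fold higher number from compound 2 to compound 3 (0.17 log units; within the scatter) as an expected shift. For compound 3 the estimated value is 6000 nM with an expected range from 2000 nM to 20000 nM in this assay.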

Compound 3, half-maximal inhibitory concentration: > 5000 nM
Compound 3: no number, only a limit (the forecaster's own chance of this, stated with the estimate: 15%); the middle value is on the limit's open side.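

In this assay compound 3 has no number, only a limit: the limit of > 5000 nM in this assay, at which 1 of the 3 values shown sits.

Going by these compounds alone, this is the first read on the aromatic carbon para to a large group, and methyl in place of hydroxy gives an at least 1.2-fold higher number from compound 2 to compound 3 (0.09 log units; that floor lies within the scatter). The limit rules out a lower number for compound 3 than for compound 2, so on this read-out the change brings no gain in inhibition, although the floor of the step does not separate the two compounds.

As far as these compounds go, how far compound 3 lies past its limit stays open, so the step could be small or large. Also open, from the compounds shown here alone, is whether the loss of hydroxy or the entry of methyl sets the result, and an amine or a carboxylic acid on the same aromatic carbon would bear on that.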